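Working notes on a fused-ring alkyne series

This account rests on a few compounds, and the source may have more. Where it says the series, first, only, none or still open, it means among the compounds named here.

Measured so far:
compound 1, `Fc1cccc(F)c1C#Cc1cnc2ccccc2c1`, gives 41.7% in a functional assay on LS174T cells (Homo sapiens) for inhibition, with a stated time of 4 days, tested at 1 uM; a lower number here means a weaker effect, a higher number a stronger effect of the compound at the concentration tested.
compound 2, `Fc1cccc(F)c1C#Cc1cc2ccccc2nc1Cl`, gives 28.4% in this assay.
compound 3, `Fc1cccc(F)c1C#Cc1ccc2ncccc2c1`, gives 11% in this assay.

From compound 1 to compound 2 the change is chloro in place of hydrogen on an aromatic carbon, and the step is a number 13.3 percentage points lower from compound 1 to compound 2 (beyond the scatter). Compound 3 stands lowest of the three; how its core differs from the core of compound 1 is not broken down here. Compound 4, `Fc1cccc(F)c1C#Cc1ccc2nc(Cl)ccc2c1`, is not yet measured; it differs from compound 3 by chloro in place of hydrogen on an aromatic carbon. This is the same kind of change as from compound 1 to compound 2, though there the place was also ortho to a large group. Resting on a number 13.3 percentage points lower from compound 1 to compound 2 (beyond the scatter), a downward step is expected for compound 4, estimated as a number 8 percentage points lower from compound 3 to compound 4 (within the scatter) in this assay. Compound 4 is expected to give about 3%, between -10% and 15%.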

Compound 4, a percentage reported as inhibition, at one concentration (the size of the read-out at that concentration, not a potency): 21.2%
For compound 4 the middle estimate is 18.2 percentage points below the measured one; the measured number lies above the stated range.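

On the core of compound 3, chloro in place of hydrogen on an aromatic carbon gives a number 10.2 percentage points higher from compound 3 to compound 4 (beyond the scatter) in this assay. Set beside the earlier step, the same change goes in opposite directions on the two cores: the same change on two cores in this assay, a number 13.3 percentage points lower (beyond the scatter) from compound 1 to compound 2 and a number 10.2 percentage points higher (beyond the scatter) from compound 3 to compound 4, 23.5 percentage points apart, beyond the scatter of two such steps. The effect of this change therefore cannot be carried from one of these cores to the other, but two pairs do not show what sets the direction, nor do they give a rule for any further core.

On these data alone, whether a methyl group, a methoxy group or an amine in the place of the chloro would follow the same split between the two cores remains open. So does whether the chloro step on either core would hold at another place on the ring.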